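A few compounds are considered here, and "the series" means these few. Any claim that something is new, unique, unknown or untested is made for them only; others in the source may bear on it.

In a functional assay on MCF7 cells (Homo sapiens) for antiproliferative activity, read by MTT assay (on this read-out lower numbers stand for stronger inhibition and higher numbers for weaker inhibition), compound 1 (`CCCCCCCCCCCCCCCC1(O)CC(=O)c2c(O)cc(O)cc2O1`) gives 17500 nM and compound 3 (`CC/C=C\C/C=C\C/C=C\CCCCCCCC1(O)CC(=O)c2c(O)cc(O)cc2O1`) gives 17500 nM, so these two stand level, with no change at the digits printed from compound 1 to compound 3 (within the scatter). Compound 2 (`CCCCCCCCCCCC1(O)CC(=O)c2c(O)cc(O)cc2O1`) gives 43200 nM, the highest number of the three, and the move to the lowest level is a 2.5-fold lower number from compound 2 to compound 3 (0.39 log units; beyond the scatter). Compound 4 (`CCCCC/C=C\C/C=C\CCCCCCCC1(O)CC(=O)c2c(O)cc(O)cc2O1`) has not yet been measured. It differs from compound 3 by butyl in place of but-1-en-1-yl on a saturated chain carbon bound to a double-bonded chain carbon. The measured chain changes were small, and the largest of them was a 2.5-fold higher number from compound 1 to compound 2 (0.39 log units; beyond the scatter). This change is a small one within the chain, so the estimated outcome in this assay is no change at the digits printed from compound 3 to compound 4 (within the scatter). Compound 4 is expected at about 17500 nM, within an estimated range of 9000 nM to 35000 nM.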

Compound 4, half-maximal inhibitory concentration: 17500 nM
Beside the measured number, compound 4's estimate shows no gap at the digits printed; the measured number falls inside the stated range.
By their numbers in this assay, from the lowest: compounds 1, 3 and 4 (each within the scatter of the next); then compound 2.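

In this assay butyl in place of but-1-en-1-yl gives no change at the digits printed from compound 3 to compound 4 (within the scatter) and so one double bond can go from this place on the chain while the number stays level. Deca-1,4-dien-1-yl in place of butyl gives a 2.5-fold lower number from compound 2 to compound 4 (0.39 log units; beyond the scatter) while deca-1,4-dien-1-yl in place of octyl gives no change at the digits printed from compound 1 to compound 4 (within the scatter) and so compound 4, with double bonds in its chain, stands with the saturated compound 1 and apart from compound 2. Nothing measured here explains these results. Still open, from the compounds shown here alone, is whether an amine or a carboxylic acid at the chain end, or a longer chain, would keep this level.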